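The source may report more compounds than this note shows. Statements on the series, on what has been measured and on what is new or still open speak of the compounds shown alone.

In a functional assay on MIA PaCa-2 cells (Homo sapiens) for inhibition, read by MTT assay, with a stated time of 7 days (on this read-out higher numbers stand for weaker inhibition and lower numbers for stronger inhibition), compound 3 `O=C([C@@H]1CCCN(S(=O)(=O)c2ccc(S(=O)(=O)N3CC[C@H](O)C3)cc2)C1)N1CCC(F)(F)CC1` gives 590 nM, the highest of the three numbers in hand. Its stereoisomer compound 1 `O=C([C@@H]1CCCN(S(=O)(=O)c2ccc(S(=O)(=O)N3CC[C@@H](O)C3)cc2)C1)N1CCC(F)(F)CC1` gives 210 nM, a step of a 2.8-fold higher number from compound 1 to compound 3 (0.45 log units; beyond the scatter) that rests only on (the fact that compounds 1 and 3 differ only in the configuration as drawn). Compound 2 `CCC(CC)S(=O)(=O)c1ccc(S(=O)(=O)N2CCC[C@@H](C(=O)N3CCC(F)(F)CC3)C2)cc1` gives 13 nM. The change from compound 3 to compound 4 `CC(C)CS(=O)(=O)c1ccc(S(=O)(=O)N2CCC[C@@H](C(=O)N3CCC(F)(F)CC3)C2)cc1` is isobutyl in place of 3-hydroxypyrrolidin-1-yl on a sulfonyl sulfur. The measured steps that bear on it are a 45-fold higher number from compound 2 to compound 3 (1.66 log units; beyond the scatter) and a 16-fold lower number from compound 1 to compound 2 (1.21 log units; beyond the scatter), both large and both in the same sense, an alkyl group taking the place of 3-hydroxypyrrolidin-1-yl on the sulfonyl sulfur. Isobutyl is taken here as another such alkyl group, so the expected step in this assay is a 24-fold lower number from compound 3 to compound 4 (1.37 log units; beyond the scatter). Compound 4 is therefore estimated at 25 nM, within 8 nM to 80 nM.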

Compound 4, half-maximal inhibitory concentration: 80 nM
For compound 4 the middle estimate is 3.2-fold (0.51 log units) below the measured one, and the stated range covers the measured number.
By their numbers in this assay, from the lowest: compound 2; then compound 4; then compound 1; then compound 3.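

Isobutyl also gives a lower number than 3-hydroxypyrrolidin-1-yl, with a 7.4-fold lower number from compound 3 to compound 4 (0.87 log units; beyond the scatter) and a 2.6-fold lower number from compound 1 to compound 4 (0.42 log units; beyond the scatter) as two readings of one replacement, and those readings start from stereoisomers: (the fact that compounds 1 and 3 differ only in the configuration as drawn). The choice of alkyl group counts as well, with a 6.2-fold higher number from compound 2 to compound 4 (0.79 log units; beyond the scatter) on going from pentan-3-yl, so the gain on this sulfonyl sulfur is not the same for each alkyl group shown.

From the compounds shown here alone, whether a longer straight chain or a cyclohexyl ring would behave like pentan-3-yl or like isobutyl stays open. The compounds shown also do not separate the loss of the hydroxyl from the loss of the ring, which change together here.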